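Compound 4 Beside Compound 1 in a Cell Viability Test

The source may report more compounds than this note shows. Statements on the series, on what has been measured and on what is new or still open speak of the compounds shown alone.

Measured in an ADME assay on NCM460 cells (Homo sapiens) for cytotoxicity, read by MTT assay, with a stated time of 72 h; on this read-out higher numbers stand for weaker inhibition and lower numbers for stronger inhibition:
- compound 1 `CCc1ccc(NC(=O)c2cccc(/C=C3\CC(=O)N(c4ccccc4)C3=O)c2)cc1` gives > 100000 nM, a limit of the assay, not a number.
- compound 2 `CCc1cccc(NC(=O)c2cccc(/C=C3\CC(=O)N(Cc4ccccc4)C3=O)c2)c1` gives > 100000 nM, again a limit.
- compound 3 `CCCCCN1C(=O)C/C(=C\c2cccc(C(=O)NCCCC)c2)C1=O` gives > 100000 nM, again a limit.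

Compound 1 stands where the other two stand: every value sits at the limit of > 100000 nM in this assay, at which 3 of the 3 values shown sit, so no number is known for any of them and no order among them can be read. Compound 4 `COc1ccc(OC)c(NC(=O)c2cccc(/C=C3\CC(=O)N(c4ccccc4)C3=O)c2)c1` differs from compound 1 in one place: 2,5-dimethoxyphenyl in place of 4-ethylphenyl on an amide-type nitrogen. For the measured compounds named here, no step between measured compounds is available, and with all values at the limit no step size can be taken from them. In this assay the change expected for compound 4 is none beyond the scatter, most probably another limit. Compound 4 is estimated at 150000 nM, between 60000 nM and 400000 nM. The estimated step that the limit leaves unreadable from compound 1 to compound 4 is expected to lie within the scatter.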

Compound 4, half-maximal inhibitory concentration: > 100000 nM
Compound 4 gave a limit, no number; the forecaster's own chance of this, stated with the estimate: 85%; the middle value is on the limit's open side.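

Compound 1 and compound 4 both sit at a limit, not a number, in this assay, so no new step can be read between them: the limit of > 100000 nM in this assay, at which 4 of the 4 values shown sit.

Going by these compounds, whether 2,5-dimethoxyphenyl in place of 4-ethylphenyl changes the value at all remains open, as does any order among the four compounds.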